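The compounds below may be only part of what the source reports. "The series", "measured", "known", "first", "only" and "open" are said of these compounds alone.

Measured compounds:
Compound 1 `Cc1cc(C)c(SCc2ncnc3c2ncn3[C@@H]2O[C@H](CO)[C@@H](O)[C@H]2O)c(C)c1` gives 33100 nM in an assay on isolated protein for binding affinity to Equilibrative nucleoside transporter 1 (Homo sapiens); a lower number here means a stronger inhibitor, a higher number a weaker inhibitor.
Compound 2 `OC[C@H]1O[C@@H](n2cnc3c(CSc4ccccc4Cl)ncnc32)[C@H](O)[C@@H]1O` gives 1780 nM in this assay.
Compound 3 `OC[C@H]1O[C@@H](n2cnc3c(CSc4ccc(OC(F)(F)F)cc4)ncnc32)[C@H](O)[C@@H]1O` gives 123 nM in this assay.

All three share the same core and differ only in the ring carried on the sulfur. Compound 3 has the lowest number of the three: compound 2 is beyond the scatter above it, and compound 1 further still. Within the data shown here, the one step recorded within this set, a 19-fold lower number from compound 1 to compound 2 (1.27 log units; beyond the scatter), shows that changing the groups on this ring can shift the number by a large amount.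

Compound 4 `CC(C)(C)c1ccc(SCc2ncnc3c2ncn3[C@@H]2O[C@H](CO)[C@@H](O)[C@H]2O)cc1` is not yet measured. It differs from compound 3 by tert-butyl in place of trifluoromethoxy on an aromatic carbon. Among the measured compounds shown here, no measured step swaps one group for another at this same place, so the size of this step is not directly known; the recorded step only shows that this ring is sensitive to change. The expectation for compound 4 is a modest shift, possibly to a weaker inhibitor, of about a 1.8-fold higher number from compound 3 to compound 4 (0.25 log units; within the scatter). Compound 4 is therefore estimated at 220 nM, within a range of 50 nM to 1000 nM.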

Compound 4, half-maximal inhibitory concentration: 331000 nM
Beside the measured number, compound 4's estimate is 1500-fold (3.18 log units) below it, and the stated range ends below it.
By their numbers in this assay, from the lowest: compound 3; then compound 2; then compound 1; then compound 4.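

In this assay, the swap of trifluoromethoxy for tert-butyl on this aromatic carbon gives a 2700-fold higher number from compound 3 to compound 4 (3.43 log units; beyond the scatter) and is the largest step in the set, so two groups with no ring and no net charge are far from interchangeable here. The 4-(tert-butyl)phenyl ring also does worse than the other two rings on the sulfur, with a 190-fold higher number from compound 2 to compound 4 (2.27 log units; beyond the scatter) and a 10-fold higher number from compound 1 to compound 4 (1.00 log units; beyond the scatter) on the same scale, so even the 2,4,6-trimethylphenyl ring is not the poorest choice at this place. Nothing measured here explains why this swap costs so much.

On these data alone, whether the loss is particular to tert-butyl remains open. An ethyl chain, a methoxy or an amine on the same carbon would show how the number moves between these two extremes.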